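Chloro to methoxy swap on the shared core

This account rests on a few compounds, and the source may have more. Where it says the series, first, only, none or still open, it means among the compounds named here.

Of the compounds shown here, two have so far been tested in an ADME assay on Huh-7 cells (Homo sapiens) for cytotoxicity, read by MTT assay, with a stated time of 72 h; on this read-out higher numbers stand for lower toxicity in this test and lower numbers for higher toxicity in this test. Compound 1, `CN(O)C(=O)c1cccc[n+]1[O-]`, sits at the limit of the assay: in this assay compound 1 gives > 1000000 nM, which is a limit and not a number, (the limit of > 1000000 nM in this assay, at which 1 of the 2 values shown sits). Going by the values given here, compound 2, `O=C(NO)c1ncccc1Cl`, supplies the only number in the set: in this assay compound 2 gives 800000 nM, so it is the sole measured position available. Compound 3, `COc1cccnc1C(=O)NO`, has not yet been measured. Compared with compound 2 it carries methoxy in place of chloro on an aromatic carbon. Among the compounds with values here, no step between measured compounds exists to calibrate this change, so the expectation rests on compound 2 alone. The expected step is a 1.1-fold higher number from compound 2 to compound 3 (0.05 log units; within the scatter), that is, no move beyond the usual scatter in either direction. On that basis compound 3 is estimated at 900000 nM in this assay, with a range from 350000 nM to 2000000 nM, and a fair chance that only a limit is reported.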

Compound 3, half-maximal cytotoxic concentration: 880000 nM
For compound 3 the middle estimate is 1.0-fold (0.01 log units) above the measured one; low and high end bracket the measured number.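

In this assay, the swap of methoxy in place of chloro on an aromatic carbon now has a measured size: a 1.1-fold higher number from compound 2 to compound 3 (0.04 log units; within the scatter). At this place, ortho to a group of 4 heavy atoms and two atoms from the ring nitrogen, the two groups therefore cannot be told apart on this read-out, even though methoxy brings a hydrogen-bond acceptor that chloro lacks. Compound 1 offers no number to set beside this step, as its entry is a limit: the limit of > 1000000 nM in this assay, at which 1 of the 3 values shown sits.

From the compounds shown here alone, whether any group at this place can move the number beyond the scatter stays open; an amine, a carboxylic acid or a longer chain would be the next contrast. Going by these compounds, with a single step on the shared core, it also remains unknown whether this swap would read the same elsewhere on the ring.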